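This account rests on a few compounds, and the source may have more. Where it says the series, first, only, none or still open, it means among the compounds named here.

Measured so far in a functional assay on SK-MEL-28 cells (Homo sapiens) for cytotoxicity, read by MTT assay, with a stated time of 3 days; a higher number here means a weaker inhibitor, a lower number a stronger inhibitor:
compound 1 `CNc1nc(SCc2nc3ccccc3[nH]2)nc(-c2ccccc2)c1C#N` gives 2.87 nM
compound 2 `N#Cc1c(Nc2nccs2)nc(SCc2nc3ccccc3[nH]2)nc1-c1ccccc1` gives 8.9 nM

Within the data shown here, compound 2 holds the higher number of the two, which makes it the weaker inhibitor, and compound 1 is its only measured neighbour. Compound 3 `N#Cc1c(NNC(N)=S)nc(SCc2nc3ccccc3[nH]2)nc1-c1ccccc1` departs from compound 2 as follows (a group of 4 heavy atoms (1 carbon, 2 nitrogen, 1 sulfur; no ring) in place of a group of 5 heavy atoms (3 carbon, 1 nitrogen, 1 sulfur; one five-membered aromatic ring with 2 hetero atoms), on a nitrogen on an aromatic ring). Among the measured compounds shown here, the one measured step at this place, on a nitrogen on an aromatic ring, is a 3.1-fold higher number from compound 1 to compound 2 (0.49 log units; beyond the scatter) and it is modest. For the measured compounds named here, no measured compound carries the entering group, so the data give no direction. A step of that modest size is conceivable either way, but the central expectation in this assay is no change beyond the scatter. For compound 3 the estimated value is 10 nM (expected range 3 nM to 35 nM). This estimate means an expected 1.1-fold higher number from compound 2 to compound 3 (0.05 log units; within the scatter) and nothing larger.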

Compound 3, half-maximal inhibitory concentration: 3.2 nM
Compound 3: middle estimate off by 3.1-fold (0.49 log units), on the high side; low and high end bracket the measured number.
By their numbers in this assay, from the lowest: compounds 1 and 3 (each within the scatter of the next); then compound 2.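

In this assay the open-chain group of compound 3, with no ring and a double bond outside aromatic rings, is accepted on this nitrogen: the step of a 2.8-fold lower number from compound 2 to compound 3 (0.44 log units; beyond the scatter) recovers what the 1,3-thiazol-2-yl group had lost. The step of a 1.1-fold higher number from compound 1 to compound 3 (0.05 log units; within the scatter) leaves the much larger open-chain group indistinguishable from methyl at this place, so size alone does not order the three compounds, and compound 2 is the only one that stands apart. No measurement on hand gives a reason for either step.

Still open, going by these compounds, is whether a longer alkyl chain or a phenyl group on this nitrogen would stay level with compound 1 and compound 3 or fall with compound 2. An unsubstituted amine at this place would show whether any substituent on the nitrogen is needed at all.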